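The source may hold more compounds than are shown below. What is called first, only, known or untested is meant among the compounds shown, and "the series" means these compounds.

Compound 1 `COc1ccc(C[C@H]2COC[C@@H]2Cc2ccc(Cl)c(Cl)c2)cc1`: 39000 nM
Compound 2 `COc1cc(C[C@H]2COC[C@@H]2Cc2ccc(Cl)c(Cl)c2)ccc1O`: 21000 nM

In a functional assay on HL-60 cells (Homo sapiens) for cytotoxicity, read by WST assay, with a stated time of 48 h (a lower number here means that less compound is needed, a higher number that more compound is needed for the effect), compound 2 gives 21000 nM, within the scatter of compound 1 at 39000 nM. Compound 3 `COc1ccc(C[C@H]2COC[C@@H]2Cc2ccc(Cl)c(Cl)c2)cc1OC` differs from compound 2 by methyl in place of hydrogen on an oxygen on an aromatic ring, that is, hydroxy to methoxy. Going by the values given here, no measured step of this kind exists. In this assay, a small move towards a higher number is expected, probably not beyond the scatter, resting only on compound 2 at 21000 nM and compound 1 at 39000 nM. The expected step is a 1.4-fold higher number from compound 2 to compound 3 (0.15 log units; within the scatter). For compound 3 the estimated value is 30000 nM, with an expected range of 14000 nM to 62000 nM.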

Compound 3, half-maximal effective concentration: 16000 nM
Estimate against measurement, compound 3: 1.9-fold (0.27 log units) above; the measured number falls inside the stated range.
By their numbers in this assay, from the lowest: compounds 3, 2 and 1 (each within the scatter of the next, the first and the last beyond it).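

In this assay, hydroxy to methoxy at this place on the aromatic ring gives no change that can be told from the scatter, with a 1.3-fold lower number from compound 2 to compound 3 (0.12 log units; within the scatter) as the step. Methoxy in place of hydrogen on an aromatic carbon gives the only step so far beyond the scatter, though a modest one, with a 2.4-fold lower number from compound 1 to compound 3 (0.39 log units; beyond the scatter) as the step. Nothing available explains either step.

Still open, from the compounds shown here alone, is whether ethoxy or a longer chain on this oxygen, or an amine or a carboxylic acid at this place, would move the number further.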